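Adding a Second Trifluoromethyl to a Chloro Analogue

A few compounds are considered here, and "the series" means these few. Any claim that something is new, unique, unknown or untested is made for them only; others in the source may bear on it.

Compound 1 `Nc1scc(-c2cccc(C(F)(F)F)c2)c1C(=O)c1ccccc1` is the reference point of this small set. In an assay on isolated protein with adenosine receptor A1 (Homo sapiens) as the target, read by ERK phosphorylation (on this read-out higher numbers stand for higher potency (the scale is a negative logarithm) and lower numbers for lower potency), compound 1 gives 6.37. Compound 2 `Nc1scc(-c2cc(C(F)(F)F)cc(C(F)(F)F)c2)c1C(=O)c1ccccc1` carries one more trifluoromethyl group, and in this assay compound 2 gives 5.22, so that a number 1.15 log units lower from compound 1 to compound 2 (beyond the scatter). Compound 3 `Nc1scc(-c2cccc(C(F)(F)F)c2)c1C(=O)c1ccc(Cl)cc1` instead carries a chloro group on the other aromatic ring; in this assay compound 3 gives 5.74, which makes a number 0.63 log units lower from compound 1 to compound 3 (beyond the scatter). Among the three measured numbers, compound 3 stands second highest, with compound 1 above it and compound 2 below it, both gaps beyond the scatter.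

Compound 4 `Nc1scc(-c2cc(C(F)(F)F)cc(C(F)(F)F)c2)c1C(=O)c1ccc(Cl)cc1` has not been measured. It differs from compound 3 in one place: trifluoromethyl in place of hydrogen on an aromatic carbon. The same change has been seen once already, and it produced a large loss, since a number 1.15 log units lower from compound 1 to compound 2 (beyond the scatter). The expectation is therefore a step of comparable size downward, estimated as a number 1.04 log units lower from compound 3 to compound 4 (beyond the scatter). On that basis compound 4 is expected to give about 4.7 in this assay, most likely between 4.1 and 5.3.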

Compound 4, negative logarithm of the antagonist equilibrium constant: 5.46
Beside the measured number, compound 4's estimate is 0.76 log units below it; the measured number lies above the stated range.
By their numbers in this assay, from the lowest: compounds 2, 4 and 3 (each within the scatter of the next, the first and the last beyond it); then compound 1.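

The second trifluoromethyl group does not carry a fixed cost at this position, since its effect depends on what the other aromatic ring bears: the same change on two cores in this assay, a number 1.15 log units lower (beyond the scatter) from compound 1 to compound 2 and a number 0.28 log units lower (within the scatter) from compound 3 to compound 4, 0.87 log units apart, beyond the scatter of two such steps. With the chloro group already present, the same change gives a number 0.28 log units lower from compound 3 to compound 4 (within the scatter). The two groups therefore do not simply add up, and the chloro group's own step reads differently once the second trifluoromethyl group is there, at a number 0.24 log units higher from compound 2 to compound 4 (within the scatter): the same change on two cores in this assay, a number 0.63 log units lower (beyond the scatter) from compound 1 to compound 3 and a number 0.24 log units higher (within the scatter) from compound 2 to compound 4, 0.87 log units apart, beyond the scatter of two such steps.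

The compounds shown leave open whether a methyl group, a methoxy group or an amine in place of the second trifluoromethyl group would depend on the chloro group in the same way. They also leave open whether a bromo group in place of the chloro group would have the same influence on this step.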